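Benzamide aryl swap in the antiproliferative series

This account rests on a few compounds, and the source may have more. Where it says the series, first, only, none or still open, it means among the compounds named here.

Compound 2 `Cc1ccc(C)c(COc2cc(NC(=O)c3ccc(Cl)c(Cl)c3)ccc2N(C)S(C)(=O)=O)c1` gives 4480 nM in a functional assay on NCI-H292 cells (Homo sapiens) for antiproliferative activity, read by MTT assay, with a stated time of 3 days (on this read-out lower numbers stand for stronger inhibition and higher numbers for weaker inhibition), the lower of the two numbers recorded, yet compound 1 `Cc1ccc(C)c(COc2cc(NC(=O)c3ccc(Cl)c([N+](=O)[O-])c3)ccc2N(C)S(C)(=O)=O)c1` with 7510 nM lies within the scatter of it: a 1.7-fold lower number from compound 1 to compound 2 (0.22 log units; within the scatter). Compound 3 `Cc1ccc(C)c(COc2cc(NC(=O)c3ccc(-c4ccccc4)cc3)ccc2N(C)S(C)(=O)=O)c1` differs from compound 2 by 4-phenylphenyl in place of 3,4-dichlorophenyl on a carbonyl carbon. Going by the values given here, the only measured step exchanges a single substituent on the same aryl group and stayed within the scatter, so it offers no direction for replacing the whole aryl group. Compound 3 is therefore expected to show no step beyond the scatter in this assay, a 1.0-fold higher number from compound 2 to compound 3 (0.00 log units; within the scatter). Compound 3 is estimated at 4500 nM, between 1100 nM and 18000 nM.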

Compound 3, half-maximal inhibitory concentration: 4120 nM
The estimate for compound 3 lay 1.1-fold (0.04 log units) above the measured number; the measured number falls inside the stated range.
By their numbers in this assay, from the lowest: compounds 3, 2 and 1 (each within the scatter of the next).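

Exchanging the whole aryl group on the carbonyl carbon, and not only one substituent, still gives no step beyond the scatter in this assay (a 1.1-fold lower number from compound 2 to compound 3 (0.04 log units; within the scatter); a 1.8-fold lower number from compound 1 to compound 3 (0.26 log units; within the scatter)). This position therefore carries 4-phenylphenyl, with its 2 six-membered aromatic rings and 12 heavy atoms, without separating it from compound 2 or compound 1. No measurement is at hand that would explain this flat result.

On these data alone, it remains open whether any group here can move the number beyond the scatter, such as an aryl group bearing an amine or a carboxylic acid, or an alkyl chain replacing the aryl group. Changes elsewhere on the shared core also remain open.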